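Side-chain change from compound 2 to compound 3

The compounds below may be only part of what the source reports. "The series", "measured", "known", "first", "only" and "open" are said of these compounds alone.

Two compounds of the series carry readings in a functional assay on the whole organism with Rattus norvegicus as the target; on this read-out higher numbers stand for an effect only at larger amounts of compound and lower numbers for an effect already at smaller amounts. Compound 1 `Nc1ccc2nc(N)sc2c1` returns only a limit in this assay, > 10 mg/kg, and no number. Among the measured compounds shown here, compound 2 `CNS(=O)(=O)CCn1c(=N)sc2cc(OC(F)(F)F)ccc21` gives 4 mg/kg in this assay and so holds the only numerical value shown. The other entry, that of compound 1, is a limit, (the limit of > 10 mg/kg in this assay, at which 1 of the 2 values shown sits). For the measured compounds named here, no pair of measured compounds differs in a single place, so no measured step is available to lean on.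

Compound 3 `CS(=O)(=O)CCCn1c(=N)sc2cc(OC(F)(F)F)ccc21` is the next candidate. It departs from compound 2 by one change on the chain: (methylsulfonyl)methyl in place of methylsulfamoyl on a saturated chain carbon, two bonds along the chain from an aromatic nitrogen. The methylsulfamoyl group leaves and the (methylsulfonyl)methyl group enters, on a saturated chain carbon, two bonds along the chain from an aromatic nitrogen.

Going by the values given here, with no measured step for guidance, the expectation in this assay is a small shift at most, within the usual scatter, leaning if anything toward larger doses. Compound 3 is therefore expected to give about 5 mg/kg in this assay, with a plausible range from 2 mg/kg to 15 mg/kg. This estimate rests on compound 2 at 4 mg/kg. The step of a 1.3-fold higher number from compound 2 to compound 3 (0.10 log units; within the scatter) is expected to stay within scatter.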

Compound 3, dose for half-maximal effect: 5 mg/kg
Estimate against measurement, compound 3: no gap at the digits printed; measured number inside the range.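

Among the compounds shown here, this is the first single-place step: in this assay, putting (methylsulfonyl)methyl in place of methylsulfamoyl on a saturated chain carbon, two bonds along the chain from an aromatic nitrogen, gives a 1.3-fold higher number from compound 2 to compound 3 (0.10 log units; within the scatter). The entering group has 0 hydrogen-bond donors where the leaving group has 1, and the nitrogen of the methylsulfamoyl group is replaced by carbon, so for this pair neither that nitrogen nor the amide hydrogen is needed to keep the read-out within the scatter; the same change can also be read as 2-(methylsulfamoyl)ethyl to 3-(methylsulfonyl)propyl. Nothing shown gives a reason why the two side chains read alike.

The compounds shown leave open how this read-out responds at the end of the chain to a carboxylic acid or a primary amine, and whether a longer chain carrying the methylsulfonyl group stays within the scatter of compound 3. For the compounds shown here, with only one step at one place, it also remains open whether the same change would read alike on a differently substituted core.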